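Swapping an acetamido for hydroxymethyl on a thromboxane antagonist scaffold

A few compounds are considered here, and "the series" means these few. Any claim that something is new, unique, unknown or untested is made for them only; others in the source may bear on it.

This account follows a single change on a shared core and asks what it should do to potency. Compound 1 `CC(=O)NCc1ccccc1-c1ccc(COC2CC[C@H](N3CCCCCC3)[C@H]2OC/C=C\CCC(=O)O)cc1` gives 25.1 nM in a functional assay on blood for antagonist activity at thromboxane A2 receptor (Homo sapiens) (a lower number here means tighter binding, a higher number weaker binding), the lower of the two numbers among the compounds with a single value. Its nearest neighbour on the numbers is compound 3 `O=C(O)CC/C=C\CO[C@@H]1C(OCc2ccc(-c3ccccc3)cc2)CC[C@@H]1N1CCCCC1`, which gives 39.8 nM in this assay, a gap that sits within the scatter of the method. Compound 2 `O=C(O)CC/C=C\CO[C@H]1[C@@H](OCc2ccc(-c3ccccc3)cc2)CC[C@@H]1N1CCCCC1` gives 10 nM; 7.94 nM (2 entries) in this assay across its repeated entries, as recorded in the several entries of compound 2 in this assay, 10 nM; 7.94 nM (2 entries); compound 2 and compound 3 are drawn differently at one centre, as noted in the fact that one of compounds 2 and 3 is drawn with a defined configuration and the other without, at the place where they differ.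

The compound still to be measured is compound 4 `O=C(O)CC/C=C\CO[C@H]1C(OCc2ccc(-c3ccccc3CCO)cc2)CC[C@@H]1N1CCCCCC1`. It differs from compound 1 in one place (hydroxymethyl in place of acetamido on a saturated chain carbon bound to an aromatic carbon). Among the compounds with values here, no measured pair in this set shows what such a swap does, so the step in this assay is expected to be small, with no clear direction beyond the scatter. Compound 4 is therefore estimated at 30 nM, within 10 nM to 90 nM, which amounts to an expected step of a 1.2-fold higher number from compound 1 to compound 4 (0.08 log units; within the scatter).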

Compound 4, dissociation constant: 2 nM
Compound 4: the middle estimate sits 15-fold (1.18 log units) above what was measured; the measured number lies below the stated range.
By their numbers in this assay, from the lowest: compound 4; then compounds 1 and 3 (each within the scatter of the next).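

In this assay, hydroxymethyl in place of acetamido on a saturated chain carbon bound to an aromatic carbon gives a 13-fold lower number from compound 1 to compound 4 (1.10 log units; beyond the scatter), so what this position carries can move the number well beyond the scatter, which no earlier pair had shown. The step comes with no change in the counts of hydrogen-bond donors and acceptors, each group having 1 of each, while the heavy atoms of the group fall from 4 to 2. Nothing recorded for these compounds bears on why the step is this large.

The compounds shown leave open whether an amine or a carboxylic acid at this place, or a longer chain ending in the same hydroxyl, would keep the lower number. They also leave open whether the same swap would give a step of like size on another core.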